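A Smaller Group on the Shared Core

A few compounds are considered here, and "the series" means these few. Any claim that something is new, unique, unknown or untested is made for them only; others in the source may bear on it.

Measured compounds:
- compound 1, `CCCCOC(=O)NS(=O)(=O)c1ccc(CCC)cc1-c1ccc(Cn2c(CCCC)nc3ccccc32)cc1`: 9.2 nM
- compound 2, `CCCc1ccc(S(=O)(=O)NC(=O)OCCCC(F)(F)F)c(-c2cc(F)c(Cn3c(C(C)(C)C)nc4ccccc43)c(F)c2)c1`: 12 nM

In an assay on membranes from HEK293 cells for displacement of a labelled ligand from Type-2 angiotensin II receptor (Homo sapiens), read by radioligand binding (on this read-out higher numbers stand for weaker inhibition and lower numbers for stronger inhibition), compound 1 gives 9.2 nM, the lowest of the two numbers in hand. Compound 2, which carries a tert-butyl group and two fluorine atoms among other changes, gives 12 nM in this assay; the two values sit within the usual scatter of each other, so the figures tell nothing about which is stronger.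

Compound 3, `CCCCOC(=O)NS(=O)(=O)c1ccc(CCC)cc1-c1ccc(Cn2c(C3CC3)nc3ccccc32)cc1`, has not yet been measured. It differs from compound 1 in one place: cyclopropyl in place of butyl on an aromatic carbon. Within the data shown here, no step between measured compounds mirrors this change, so there is no direct guide to its size. Because compound 2 with its tert-butyl group at the same place reaches 12 nM, the expected step is a 1.6-fold higher number from compound 1 to compound 3 (0.21 log units; within the scatter), no larger than the scatter. Compound 3 is thus estimated at 15 nM, with a range from 5 nM to 45 nM.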

Compound 3, inhibition constant: 31 nM
Compound 3: middle estimate off by 2.1-fold (0.32 log units), on the low side; measured number inside the range.
By their numbers in this assay, from the lowest: compounds 1 and 2 (each within the scatter of the next); then compound 3.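

In this assay, among these compounds, the change to cyclopropyl in place of butyl, on the aromatic carbon between two ring nitrogen atoms, gives a 3.4-fold higher number from compound 1 to compound 3 (0.53 log units; beyond the scatter) and is the only step here that can be read in one place. It shows that this position does not treat these two small carbon groups alike: with one carbon fewer and a three-membered ring, the number moves modestly towards weaker inhibition. Nothing at hand explains the step, so no cause can be named for it.

Whether the shorter group or the ring accounts for the step stays open, with neither a propyl chain nor a longer chain such as pentyl among the compounds shown at this carbon. On these data alone, how a cyclobutyl ring or an amine at the same place would read in this assay also remains unknown.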